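This account rests on a few compounds, and the source may have more. Where it says the series, first, only, none or still open, it means among the compounds named here.

Measured so far in a functional assay (trachea) with Cavia porcellus as the target; on this read-out higher numbers stand for an effect only at larger amounts of compound and lower numbers for an effect already at smaller amounts:
- compound 1 `CCCn1c(=O)n(C)c(=O)c2c1ncn2CCOCC`: 4600 nM
- compound 2 `CCCn1c(=O)n(C)c(=O)c2c1ncn2CC(C)=O`: 1900 nM

Of these two numbers, compound 2 holds the lower, at 1900 nM. Within the data shown here, its only neighbour is compound 1, and the gap between them lies beyond the scatter.

The next compound is compound 3 `CCCn1c(=O)n(C)c(=O)c2c1ncn2CCC(C)=O`, still to be measured in this assay. The change from compound 2 is 2-oxopropyl in place of acetyl on a saturated chain carbon bound to an aromatic nitrogen. In words, this is 2-oxopropyl in place of acetyl on a saturated chain carbon bound to an aromatic nitrogen.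

Among the measured compounds shown here, no measured step covers this exact change. The nearest guide is a 2.4-fold lower number from compound 1 to compound 2 (0.38 log units; beyond the scatter), a modest step at the same place on the molecule. With a single step to go on, direction is poorly defined. A step no larger than that one is expected, with a slight lean towards a higher number. The expected step is a 1.3-fold higher number from compound 2 to compound 3 (0.12 log units; within the scatter), which would not be a clear separation. For compound 3 the estimated value is 2500 nM, with an expected range from 1000 nM to 6000 nM.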

Compound 3, half-maximal effective concentration: 12200 nM
Beside the measured number, compound 3's estimate is 4.9-fold (0.69 log units) below it, and the stated range ends below it.
By their numbers in this assay, from the lowest: compound 2; then compound 1; then compound 3.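

In this assay, the change to 2-oxopropyl in place of acetyl on a saturated chain carbon bound to an aromatic nitrogen gives a 6.4-fold higher number from compound 2 to compound 3 (0.81 log units; beyond the scatter) and shows that this position responds to chain length alone, since the carbonyl is retained and the hydrogen-bond donor and acceptor counts of the two groups are the same. Acetyl in place of ethoxy on a saturated chain carbon, two bonds along the chain from an aromatic nitrogen, gives a 2.7-fold higher number from compound 1 to compound 3 (0.42 log units; beyond the scatter) and shows that a ketone in this side chain does not by itself lower the number: compound 2 and compound 3 both carry one, yet the printed values place them on opposite sides of compound 1. No measurement available here accounts for either shift.

Going by these compounds, whether the number keeps rising with a still longer ketone chain such as 3-oxobutyl remains open, as three compounds do not define a trend with length. On these data alone, it is also open how this position would respond to a terminal amine or a carboxylic acid on the same chain, and whether any such group would take the number lower than that of compound 2.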